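Replacing carbamoyl with fluoro in a urea series

The source may hold more compounds than are shown below. What is called first, only, known or untested is meant among the compounds shown, and "the series" means these compounds.

Compound 1 `Cc1cc(NC(=O)Nc2ccc(Cl)c(Cl)c2)c2ccccc2n1` gives 23000 nM
Compound 2 `Cc1cc(NC(=O)Nc2cccc(C(N)=O)c2)c2ccccc2n1` gives > 25000 nM

In an ADME assay on BJ cells (Homo sapiens) for cytotoxicity, with a stated time of 72 h (a lower number here means that less compound is needed, a higher number that more compound is needed for the effect), compound 2 gives > 25000 nM as a limit of the assay, not a number. Compound 3 `Cc1cc(NC(=O)Nc2cccc(F)c2)c2ccccc2n1` has fluoro in place of carbamoyl on an aromatic carbon and keeps the rest of the structure of compound 2. For the measured compounds named here, no measured pair shows this change directly. Compound 1 also lacks the carbamoyl and gives 23000 nM in this series, so no shift beyond the usual scatter is expected, in either direction. The expected step of an at least 1.0-fold lower number from compound 2 to compound 3 (0.03 log units; that floor lies within the scatter) is therefore small. For compound 3 the estimated value is 23000 nM with an expected range from 11000 nM to 40000 nM in this assay once measured. The assay may again report only a limit.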

Compound 3, half-maximal effective concentration: > 25000 nM
Compound 3: a limit, no number (the forecaster's own chance of this, stated with the estimate: 55%); middle value at least 1.0-fold (0.03 log units) from the limit.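

Compound 2 and compound 3 both give only a limit, so no step between them can be read: the limit of > 25000 nM in this assay, at which 2 of the 3 values shown sit.

The compounds shown leave open whether fluoro in place of carbamoyl shifts the concentration needed in this assay at all.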